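This account rests on a few compounds, and the source may have more. Where it says the series, first, only, none or still open, it means among the compounds named here.

Compound 1 `Cc1nc2cc(OC[C@H](O)CN3CCN(Cc4noc(-c5ccc(C(F)(F)F)cc5)n4)CC3)ccc2s1`: 380 nM. Compound 2 `Cc1nc2cc(OC[C@H](O)CN3CCN(Cc4noc(-c5ccc(Cl)cc5Cl)n4)CC3)ccc2s1`: 130 nM. Compound 3 `Cc1nc2cc(OC[C@H](O)CN3CCN(Cc4noc(-c5ccc(C#N)cc5)n4)CC3)ccc2s1`: 4410 nM.

All three share one core and differ only in the aryl group on the five-membered ring. In a functional assay on mitochondria from heart for inhibition of peroxisomal acyl-coenzyme A oxidase 1 (Rattus norvegicus) (on this read-out higher numbers stand for weaker inhibition and lower numbers for stronger inhibition), compound 3 gives the highest number of the three, so it is the weakest inhibitor of this set: the step of a 12-fold higher number from compound 1 to compound 3 (1.06 log units; beyond the scatter) and the step of a 34-fold higher number from compound 2 to compound 3 (1.53 log units; beyond the scatter) both lie well beyond the scatter. Compound 4 `Cc1nc2cc(OC[C@H](O)CN3CCN(Cc4noc(-c5cccc(Cl)c5)n4)CC3)ccc2s1` has not yet been measured. Going from compound 3 to compound 4, (3-chlorophenyl in place of 4-cyanophenyl on an aromatic carbon). The step of a 34-fold higher number from compound 2 to compound 3 (1.53 log units; beyond the scatter) bears most on this change, since it too exchanges a chlorine-bearing phenyl for the 4-cyanophenyl, and a 12-fold higher number from compound 1 to compound 3 (1.06 log units; beyond the scatter) points the same way. A large step back down in this assay is therefore expected, an 8.8-fold lower number from compound 3 to compound 4 (0.95 log units; beyond the scatter). Compound 4 is expected to give about 500 nM in this assay, plausibly between 120 nM and 2000 nM.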

Compound 4, half-maximal inhibitory concentration: 4120 nM
For compound 4 the middle estimate is 8.2-fold (0.92 log units) below the measured one; measured number outside the range, above it.
By their numbers in this assay, from the lowest: compound 2; then compound 1; then compounds 4 and 3 (each within the scatter of the next).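

In this assay, a chlorine-bearing phenyl at this position does not by itself give a low number, as 3-chlorophenyl in place of 2,4-dichlorophenyl gives a 32-fold higher number from compound 2 to compound 4 (1.50 log units; beyond the scatter) and the two chlorine-bearing groups clearly part. Replacing 4-cyanophenyl gives a 1.1-fold lower number from compound 3 to compound 4 (0.03 log units; within the scatter) so 3-chlorophenyl and 4-cyanophenyl cannot be told apart here. Against 4-(trifluoromethyl)phenyl, the change gives an 11-fold higher number from compound 1 to compound 4 (1.04 log units; beyond the scatter) and so 3-chlorophenyl also falls well short of that group.

Still open, from the compounds shown here alone, is how 4-chlorophenyl or an aminophenyl group would behave at this position. No measurement here explains these differences.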